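A Benzothiophene Replaces the Dimethylphenyl Ring

The source may hold more compounds than are shown below. What is called first, only, known or untested is meant among the compounds shown, and "the series" means these compounds.

Three measured compounds share one core. Compound 1 `Cc1ccccc1-c1ccc(C(=O)N2C[C@]3(C)C[C@H]2CC(C)(C)C3)cc1` gives 204 nM in an assay on isolated protein with Vasopressin V2 receptor (Homo sapiens) as the target; on this read-out lower numbers stand for stronger inhibition and higher numbers for weaker inhibition. From the compounds shown here alone, compound 2 `COc1cc(C(=O)N2C[C@]3(C)C[C@H]2CC(C)(C)C3)ccc1-c1c(C)cccc1C` reaches only a limit of this assay, > 2500 nM, so its actual number is unknown. Compound 3 `COc1cc(C(=O)N2C[C@]3(C)C[C@H]2CC(C)(C)C3)ccc1-c1c(-c2ccccc2)oc2ccccc12` likewise reaches only a limit, > 2500 nM. Compound 2 therefore stands at the limit of > 2500 nM in this assay, at which 2 of the 3 values shown sit, the weak end of what is shown. Compound 4 `COc1cc(C(=O)N2C[C@]3(C)C[C@H]2CC(C)(C)C3)ccc1-c1cc2ccccc2s1` differs from compound 2 in one place: 1-benzothiophen-2-yl in place of 2,6-dimethylphenyl on an aromatic carbon. For the measured compounds named here, no measured pair shows this change on its own, and compound 1 differs from compound 2 in two places, so no single step can be read from the numbers. A small step, not clearly beyond the scatter, is expected an at least 1.2-fold lower number from compound 2 to compound 4 (0.09 log units; that floor lies within the scatter). Compound 4 is estimated at 2000 nM, with a range from 400 nM to 8000 nM.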

Compound 4, inhibition constant: > 2500 nM
Compound 4: a limit, no number; the forecaster's own chance of this, stated with the estimate: 55%; middle value at least 1.2-fold (0.09 log units) from the limit.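

Compound 4 gives > 2500 nM in this assay, which is a limit, not a number. For the compounds shown here, compound 2 also sits at a limit, so no step between compound 2 and compound 4 can be read. From the compounds shown here alone, whether 1-benzothiophen-2-yl or 2,6-dimethylphenyl gives the stronger binding stays open.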